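The source may report more compounds than this note shows. Statements on the series, on what has been measured and on what is new or still open speak of the compounds shown alone.

Working notes on the series. Compound 1 `C/C(=N\NC(=O)CC#N)c1ccc(NS(=O)(=O)c2ccc(Cl)cc2)cc1` and compound 2 `CCOC(=O)c1c(-c2ccco2)c(C#N)c(=O)n(/N=C(\C)c2ccc(NS(=O)(=O)c3ccc(Cl)cc3)cc2)c1N` have both been run in a functional assay on HepG2 cells (Homo sapiens) for cytotoxicity, read by sulforhodamine B assay, with a stated time of 48 h; a higher number here means a weaker inhibitor, a lower number a stronger inhibitor. Compound 1 gives 8000 nM. Compound 2 gives 10300 nM and so carries the highest of the two numbers, but its gap to compound 1 lies within the scatter, so no order between the two can be read from these values. Compound 3 `CCOC(=O)c1c(-c2ccccc2)c(C#N)c(=O)n(/N=C(\C)c2ccc(NS(=O)(=O)c3ccc(Cl)cc3)cc2)c1N` has not yet been measured. It differs from compound 2 in one place: phenyl in place of furan-2-yl on an aromatic carbon. For the measured compounds named here, no step between measured compounds covers this exchange, so nothing in the data sets its direction. Going by the values given here, the only comparison available is that compound 1 at 8000 nM and compound 2 at 10300 nM sit close together although their structures differ far more than compound 2 and compound 3 do, which gives no reason to expect a move beyond the scatter here. For compound 3 the expected result in this assay is 9500 nM, with a range from 4000 nM to 25000 nM. The step from compound 2 to compound 3 is expected to be a 1.1-fold lower number from compound 2 to compound 3 (0.04 log units; within the scatter), within the scatter.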

Compound 3, half-maximal inhibitory concentration: 16800 nM
Compound 3: the middle estimate sits 1.8-fold (0.25 log units) below what was measured; the measured number falls inside the stated range.
By their numbers in this assay, from the lowest: compounds 1, 2 and 3 (each within the scatter of the next, the first and the last beyond it).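

In this assay, for the compounds shown here, phenyl in place of furan-2-yl on the aromatic carbon opposite the ring nitrogen gives a 1.6-fold higher number from compound 2 to compound 3 (0.21 log units; within the scatter), the first step that isolates a single place on the shared core. At this position, a five-membered aromatic ring with 1 hetero atom and a six-membered aromatic ring of carbon only cannot be told apart in this read-out, even though the exchange adds a heavy atom and removes the hydrogen-bond acceptor counted on furan-2-yl. No measurement to hand bears on why this step has the size it has.

As far as these compounds go, the two compounds compared here both carry an aromatic ring at this position, so it remains open whether a group of another kind, such as an amine, a carboxylic acid or a longer alkyl chain, would move the number beyond the scatter. Going by these compounds alone, also open is what the ethoxycarbonyl and cyano groups, present in both compound 2 and compound 3, contribute, since neither group changes in the single step available.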